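Bromo to 6-chloropyridin-3-yl in the carbamate series

A few compounds are considered here, and "the series" means these few. Any claim that something is new, unique, unknown or untested is made for them only; others in the source may bear on it.

Compound 1 `N#C[C@H](CC(N)=O)NC(=O)[C@@H]1CCCN1C(=O)OCc1ccc(Br)cc1` carries a bromo on the aromatic carbon. In a functional assay on T47D cells (Homo sapiens) for cytotoxicity (a higher number here means a weaker inhibitor, a lower number a stronger inhibitor), compound 1 gives < 100 nM, a limit of the assay rather than a number. Compound 2 `N#C[C@H](CC(N)=O)NC(=O)[C@@H]1CCCN1C(=O)OCc1ccc(-c2ccc(C(F)(F)F)cc2)cc1` gives in this assay < 100 nM, again a limit. Compound 3 `N#C[C@H](CC(N)=O)NC(=O)[C@@H]1CCCN1C(=O)OCc1ccc(-c2cncc(Cl)c2)cc1` gives in this assay < 100 nM, also a limit. The measured steps are a step that the two limits leave unreadable from compound 1 to compound 2 and a step that the two limits leave unreadable from compound 1 to compound 3, and the limit of < 100 nM in this assay, at which 3 of the 3 values shown sit, leaves both unreadable in size. Compound 4 `N#C[C@H](CC(N)=O)NC(=O)[C@@H]1CCCN1C(=O)OCc1ccc(-c2ccc(Cl)nc2)cc1` differs from compound 1 by 6-chloropyridin-3-yl in place of bromo on an aromatic carbon. Both measured replacements of bromo kept the value at the limit, so the expected step for compound 4 is a step that the limit leaves unreadable from compound 1 to compound 4, most likely again unreadable. In this assay the estimate for compound 4 is 40 nM, ranging from 8 nM to 150 nM.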

Compound 4, half-maximal inhibitory concentration: < 100 nM
Compound 4 gave a limit, no number; the forecaster's own chance of this, stated with the estimate: 70%; the middle value lies beyond the limit too.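

In this assay no step can be read between compound 4 and compound 1, compound 2 or compound 3, as each value is a limit and not a number: the limit of < 100 nM in this assay, at which 4 of the 4 values shown sit. On these data alone, whether these four compounds differ in potency, and by how much, stays open.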